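The compounds below may be only part of what the source reports. "The series", "measured", "known", "first", "only" and "open" are said of these compounds alone.

Within the data shown here, compound 2 `O=C(Nc1ccc(F)c(-c2nc3ncc(-c4ccc(F)c(F)c4)cc3[nH]2)c1)N1CCCC1` gives the highest of the two numbers so far in an ADME assay on the whole organism (Mus musculus, strain Swiss Webster) for pharmacokinetics, read by LC-MS, at a dose of 50 mg/kg by the oral route (on this read-out higher numbers stand for higher exposure at the dose given and lower numbers for lower exposure), with 12000 ng.h/mL; the nearest is compound 1 `O=C(Nc1ccc(F)c(-c2nc3ncc(-c4cc(F)cc(F)c4)cc3[nH]2)c1)N1CCCC1`, which gives 9400 ng.h/mL in this assay, and the step of a 1.3-fold higher number from compound 1 to compound 2 (0.11 log units; within the scatter) lies within the scatter. Compound 3 `O=C(Nc1ccc(F)c(-c2nc3ncc(-c4ccc(O)cc4)cc3[nH]2)c1)N1CCCC1` is not yet measured. It differs from compound 2 by 4-hydroxyphenyl in place of 3,4-difluorophenyl on an aromatic carbon. Among the measured compounds shown here, only one measured step touches the same position, and that step, a 1.3-fold higher number from compound 1 to compound 2 (0.11 log units; within the scatter), exchanged one fluorine pattern for another without moving the number beyond the scatter. For the measured compounds named here, no measured pair shows what a hydroxyl at this position does, so the expectation rests on the value of compound 2 alone and carries a wide range. Compound 3 is therefore expected to give 7000 ng.h/mL in this assay, between 1500 ng.h/mL and 25000 ng.h/mL, a step of a 1.7-fold lower number from compound 2 to compound 3 (0.23 log units; within the scatter) that is itself an estimate.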

Compound 3, area under the concentration-time curve: 137 ng.h/mL
The estimate for compound 3 lay 51-fold (1.71 log units) above the measured number; measured number outside the range, below it.
By their numbers in this assay, from the lowest: compound 3; then compounds 1 and 2 (each within the scatter of the next).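

In this assay this position proves far more sensitive than the exchange of fluorine patterns suggested: 4-hydroxyphenyl in place of 3,4-difluorophenyl brings an 88-fold lower number from compound 2 to compound 3 (1.94 log units; beyond the scatter) and 4-hydroxyphenyl in place of 3,5-difluorophenyl brings a 69-fold lower number from compound 1 to compound 3 (1.84 log units; beyond the scatter) on the same core. The position therefore tolerates a move of the fluorines but not this exchange of both fluorines for a hydroxyl, which is the only one of the changes shown that adds a hydrogen-bond donor. Nothing available bears on why the number falls so far.

The compounds shown leave open whether the fall follows the hydroxyl itself or the loss of the fluorines. A methoxy group or a single fluorine at the same ring carbon would separate the two, and an amine there would show whether another hydrogen-bond donor gives a similar number.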